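This account rests on a few compounds, and the source may have more. Where it says the series, first, only, none or still open, it means among the compounds named here.

Working notes on the series. The shared core of compound 3 `CCCCCCCCCCCCCCCCCCNC(=O)[C@@H](NC(=O)c1nccc2ccccc12)[C@@H](C)O` carries a long alkyl amide and an amide-linked acyl group; in a functional assay on HepG2 cells (Homo sapiens) for cytotoxicity, read by MTT assay, with a stated time of 48 h (a lower number here means a stronger inhibitor, a higher number a weaker inhibitor), compound 3 gives 96900 nM. Within the numbers at hand compound 3 stands highest, and its nearest neighbour is compound 2 `CCCCCCCCCCCCCCCCCCNC(=O)[C@@H](NC(=O)c1ccco1)[C@@H](C)O`, which in this assay gives 42300 nM; the step of a 2.3-fold higher number from compound 2 to compound 3 (0.36 log units; beyond the scatter) is the only fully measured step in the set. Compound 1 `C/C=C/C=C/C(=O)N[C@H](C(=O)NCCCCCCCCCCCCCC)[C@@H](C)O` carries the penta-1,3-dien-1-yl carbonyl on a shorter chain, and in this assay compound 1 reaches only a limit, > 400000 nM, as noted in the limit of > 400000 nM in this assay, at which 1 of the 3 values shown sits.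

Compound 4 `C/C=C/C=C/C(=O)N[C@H](C(=O)NCCCCCCCCCCCCCCCCCC)[C@@H](C)O` is the next step: penta-1,3-dien-1-yl in place of isoquinolin-1-yl on a carbonyl carbon. Among the measured compounds shown here, no measured step covers this exchange directly. For the measured compounds named here, the one measured step, from a furan-2-yl to an isoquinolin-1-yl group, raised the number modestly; the exchange to the open penta-1,3-dien-1-yl chain is a larger change in the group on that carbonyl carbon, and the nearest structural relative, compound 1, sits at a limit. A further rise in this assay is therefore expected, of the order of a 2.1-fold higher number from compound 3 to compound 4 (0.31 log units; beyond the scatter), with a real chance that only a limit is reported. The estimate for compound 4 in this assay is 200000 nM, within a range of 60000 nM to 500000 nM.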

Compound 4, half-maximal inhibitory concentration: 284000 nM
Estimate against measurement, compound 4: 1.4-fold (0.15 log units) below; the range from low to high includes it.
By their numbers in this assay, from the lowest: compound 2; then compound 3; then compound 4. At a limit, above all of these: compound 1.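

In this assay, the group on the carbonyl carbon whose other neighbour is the amide-type nitrogen now has three measured members on the same long chain: a 2.9-fold higher number from compound 3 to compound 4 (0.47 log units; beyond the scatter), and a 6.7-fold higher number from compound 2 to compound 4 (0.83 log units; beyond the scatter). Both steps lie beyond the scatter, so the open penta-1,3-dien-1-yl group, which has no ring, carries the highest number of the three, above both furan-2-yl and isoquinolin-1-yl, although this rests on compounds 2, 3 and 4 alone. Compound 4 also gives the first look at the chain, with butyl in place of hydrogen on a saturated chain carbon, but an at least 1.4-fold lower number from compound 1 to compound 4 (0.14 log units; that floor lies within the scatter), so the size of this change remains unresolved, and the value of compound 1 is a limit and not a number: the limit of > 400000 nM in this assay, at which 1 of the 4 values shown sits.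

The compounds shown leave open whether an amine or a carboxylic acid in place of penta-1,3-dien-1-yl on that carbonyl carbon would lower the number in this assay. They also leave open how a longer chain than that of compound 4 would read, and why the three groups fall in this order.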